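The compounds below may be only part of what the source reports. "The series", "measured", "known", "first", "only" and "open" are said of these compounds alone.

Measured so far in a functional assay on SW-620 cells (Homo sapiens) for inhibition, read by sulforhodamine B assay, with a stated time of 48 h; a lower number here means a stronger inhibitor of growth, a higher number a weaker inhibitor of growth:
compound 1 `Nc1cc(N)c2nc(-c3ccccc3)c(Oc3ccc(Cl)c(Cl)c3)nc2c1` gives 9770 nM.
compound 3 `Nc1cc(N)c2nc(-c3ccccc3)c(NCc3ccc(Cl)c(Cl)c3)nc2c1` gives 3240 nM.
compound 2 `CCOC(=O)[C@H](CCC(=O)O)NC(=O)c1ccc(CNc2nc3cc(N)cc(N)c3nc2-c2ccccc2)cc1` gives < 100000 nM, which is a limit of the assay and not a number.

Of the two numbers in this assay, compound 3 holds the lower one, and compound 1 stands beyond the usual scatter from it. For compound 2 only the limit of < 100000 nM in this assay, at which 1 of the 3 values shown sits, is known.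

Compound 4 `COc1ccc(CNc2nc3cc(N)cc(N)c3nc2-c2ccccc2)cc1OC` differs from compound 3 in one place: 3,4-dimethoxyphenyl in place of 3,4-dichlorophenyl on a saturated chain carbon bound to a nitrogen on an aromatic ring. Within the data shown here, no pair among the measured compounds isolates this change, so the expectation rests on the change alone. The step from compound 3 to compound 4 is expected to be a 2.5-fold higher number from compound 3 to compound 4 (0.39 log units; beyond the scatter), toward a weaker inhibitor of growth. Compound 4 is therefore estimated at 8000 nM, with a likely range from 2500 nM to 30000 nM.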

Compound 4, concentration for 50% growth inhibition: 5250 nM
Compound 4: middle estimate off by 1.5-fold (0.18 log units), on the high side; measured number inside the range.
By their numbers in this assay, from the lowest: compounds 3, 4 and 1 (each within the scatter of the next, the first and the last beyond it).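

At this place, on a saturated chain carbon bound to a nitrogen on an aromatic ring, 3,4-dimethoxyphenyl in place of 3,4-dichlorophenyl gives a 1.6-fold higher number from compound 3 to compound 4 (0.21 log units; within the scatter) in this assay. The group that enters carries hydrogen-bond acceptors and the one that leaves carries none, yet compound 3 and compound 4 stay within the scatter of each other. No measurement shown here bears on why. Going by these compounds, whether a longer chain at this place, or an amine or a carboxylic acid on this ring, would stand beyond the scatter from compound 3 stays open.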